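Ethyl for methyl on the succinimide-bearing chain carbon

This account rests on a few compounds, and the source may have more. Where it says the series, first, only, none or still open, it means among the compounds named here.

Measured compounds:
Compound 1, `CC(C(=O)NCc1ccc(Cl)cc1)N1C(=O)CCC1=O`: 43.6 mg/kg
Compound 2, `CC(C(=O)NCc1ccc(C(F)(F)F)cc1)N1C(=O)CCC1=O`: 54.5 mg/kg
Compound 3, `CCC(C(=O)NCc1cccc(C(F)(F)F)c1)N1C(=O)CCC1=O`: 77.4 mg/kg

In a functional assay on the whole organism (strain Albino Swiss CD1) with Mus musculus as the target (a lower number here means that less compound is needed, a higher number that more compound is needed for the effect), compound 2 gives 54.5 mg/kg, the second highest of the three measured values. Its nearest neighbour is compound 1, which gives 43.6 mg/kg, and the step of a 1.3-fold higher number from compound 1 to compound 2 (0.10 log units; within the scatter) lies within the scatter. Among the measured compounds shown here, compound 3 gives 77.4 mg/kg, a value that also sits within the scatter of compound 2; no single-point step links these two, since they differ in two places.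

The unmeasured compound 4, `CCC(C(=O)NCc1ccc(C(F)(F)F)cc1)N1C(=O)CCC1=O`, differs from compound 2 by methyl in place of hydrogen on a saturated chain carbon, two bonds along the chain from an amide-type nitrogen in a ring and a carbonyl carbon. For the measured compounds named here, none of the measured steps concerns this change: the only recorded step exchanges one aromatic substituent for another and was within the scatter. What the values of compound 2 and compound 3 show is that a compound carrying the ethyl chain lies close to one carrying the methyl chain. On this basis no step beyond the scatter is expected, and the estimate for compound 4 is 62 mg/kg, with a range from 30 mg/kg to 130 mg/kg; this corresponds to an expected step of a 1.1-fold higher number from compound 2 to compound 4 (0.06 log units; within the scatter).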

Compound 4, dose for half-maximal effect: 80.4 mg/kg
Compound 4: middle estimate off by 1.3-fold (0.11 log units), on the low side; measured number inside the range.
By their numbers in this assay, from the lowest: compounds 1, 2, 3 and 4 (each within the scatter of the next).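

Among the compounds shown here, compound 2 and compound 4 form the first pair that isolates this chain carbon: they differ only in methyl in place of hydrogen. In this assay this change gives a 1.5-fold higher number from compound 2 to compound 4 (0.17 log units; within the scatter).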